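Swapping Methyl for Methoxy, a Small Step Repeated

The source may report more compounds than this note shows. Statements on the series, on what has been measured and on what is new or still open speak of the compounds shown alone.

Compound 1 `Cc1ccc(C2CC(c3ccccc3)=NN2)cc1` and compound 2 `COc1ccc(C2CC(c3ccccc3)=NN2)cc1` share one core and differ in a single place: methoxy in place of methyl on an aromatic carbon. In an assay for inhibition of cathepsin H (Capra hircus), using Lineweaver-Burk analysis (on this read-out higher numbers stand for weaker inhibition and lower numbers for stronger inhibition), compound 1 gives 8200 nM, and compound 2 gives 9800 nM; the step is a 1.2-fold higher number from compound 1 to compound 2 (0.08 log units; within the scatter). Compound 3 `Cc1ccc(-c2cc(-c3ccccc3)nn2-c2ccccc2)cc1` is built on another core, and how that core differs from the core of compound 1 is not broken down here. In this assay compound 3 gives 7400 nM. Compound 4 `COc1ccc(-c2cc(-c3ccccc3)nn2-c2ccccc2)cc1` stands to compound 3 as compound 2 stands to compound 1, the same change: methoxy in place of methyl on an aromatic carbon. Because the earlier change gave only a 1.2-fold higher number from compound 1 to compound 2 (0.08 log units; within the scatter), a similarly small step is expected here, a 1.2-fold higher number from compound 3 to compound 4 (0.08 log units; within the scatter). In this assay compound 4 is therefore estimated to give 8900 nM, most likely between 4500 nM and 18000 nM.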

Compound 4, inhibition constant: 3330 nM
Compound 4: the middle estimate sits 2.7-fold (0.43 log units) above what was measured; the whole stated range lies above it.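

On the core of compound 3, methoxy in place of methyl gives a 2.2-fold lower number from compound 3 to compound 4 (0.35 log units; beyond the scatter) in this assay and this counts as a modest step. Among these compounds, with only two pairs of compounds, this neither proves that the change carries over unaltered from one core to another nor shows that the core alters its effect. The two steps look unlike at first sight, yet they cannot be told apart: the same change on two cores in this assay, a 1.2-fold higher number (0.08 log units; within the scatter) from compound 1 to compound 2 and a 2.2-fold lower number (0.35 log units; beyond the scatter) from compound 3 to compound 4, 2.7-fold (0.42 log units) apart, within the scatter of two such steps

Going by these compounds, only methyl and methoxy appear at this place on the ring, so what a longer chain such as ethoxy, an amine or a carboxylic acid would do there stays open. On these data alone, whether the same change behaves alike on further cores also stays open.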